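The source may report more compounds than this note shows. Statements on the series, on what has been measured and on what is new or still open speak of the compounds shown alone.

Measured compounds:
- compound 1 `COc1ccc(-c2cs/c(=N/NC(=O)CSc3nnnn3-c3ccccc3)n2-c2ccccc2)cc1`: "not determined" (no result reported)
- compound 2 `O=C(CSc1nnnn1-c1ccccc1)N/N=c1/scc(-c2ccc(Cl)cc2)n1-c1ccccc1`: > 200 ug/mL

In a functional assay on C6 cells (Rattus norvegicus) for cytotoxicity, read by MTT assay, with a stated time of 24 h (on this read-out higher numbers stand for weaker inhibition and lower numbers for stronger inhibition), compound 1 has no result, so it stands nowhere on the numbers shown. Compound 2 reaches only the limit of this assay, > 200 ug/mL, which is not a number (the limit of > 200 ug/mL in this assay, at which 1 of the 2 values shown sits). Compound 3 `COc1ccc(-c2cs/c(=N/NC(=O)CSc3ncccn3)n2-c2ccccc2)cc1` differs from compound 1 by pyrimidin-2-yl in place of 1-phenyl-1H-tetrazol-5-yl on a sulfur, in words: pyrimidin-2-yl in place of 1-phenyl-1H-tetrazol-5-yl on a sulfur. Going by the values given here, no measured step covers this change, so no direction beyond the scatter can be stated. Compound 3 is expected to sit near the limit again, estimated at 200 ug/mL with a range of 100 ug/mL to 400 ug/mL.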

Compound 3, half-maximal inhibitory concentration: 102 ug/mL
Compound 3: the middle estimate sits 2.0-fold (0.29 log units) above what was measured; low and high end bracket the measured number.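

No new step can be read from compound 3: its closest partner, compound 1, carries no number in this assay. On these data alone, whether pyrimidin-2-yl in place of 1-phenyl-1H-tetrazol-5-yl on a sulfur shifts the value stays open.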